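A few compounds are considered here, and "the series" means these few. Any claim that something is new, unique, unknown or untested is made for them only; others in the source may bear on it.

In a functional assay on HCT-116 cells (Homo sapiens) for antiproliferative activity, read by MTT assay, with a stated time of 72 h (a lower number here means a stronger inhibitor, a higher number a weaker inhibitor), compound 1 `O=C(Nc1ccc(Nc2nccc(NC3CCCCC3)n2)cc1)Nc1ccc(Cl)c(C(F)(F)F)c1` gives 5950 nM. Compound 3 `O=C(Nc1ccc(Nc2nccc(Nc3cccc(Cl)c3)n2)cc1)Nc1ccc(Cl)c(C(F)(F)F)c1` gives 4820 nM, and the two sit level, with a 1.2-fold lower number from compound 1 to compound 3 (0.09 log units; within the scatter). Compound 2 `O=C(Nc1ccc(Nc2nccc(Nc3ccccc3)n2)cc1)Nc1ccc(Cl)c(C(F)(F)F)c1` reads > 50000 nM, which is a limit of the assay and not a number.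

Compound 4 `O=C(Nc1ccc(Nc2nccc(Nc3ccc(Cl)cc3)n2)cc1)Nc1ccc(Cl)c(C(F)(F)F)c1` is still unmeasured. It carries 4-chlorophenyl in place of cyclohexyl on a nitrogen on an aromatic ring.

Going by the values given here, three measured steps bear on this change. Phenyl in place of cyclohexyl gave an at least 8.4-fold higher number from compound 1 to compound 2 (0.92 log units; beyond the scatter). Chloro in place of hydrogen on an aromatic carbon then gave an at least 10-fold lower number from compound 2 to compound 3 (1.01 log units; beyond the scatter). Among the compounds with values here, the closest precedent is 3-chlorophenyl in place of cyclohexyl, which gave a 1.2-fold lower number from compound 1 to compound 3 (0.09 log units; within the scatter). On that precedent, no step beyond the scatter is expected in this assay, although the loss seen with phenyl leaves more room for a higher number than for a lower one. The expected change is a 1.0-fold higher number from compound 1 to compound 4 (0.00 log units; within the scatter). For compound 4 the estimated value is 6000 nM, with an expected range from 2000 nM to 25000 nM.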

Compound 4, half-maximal inhibitory concentration: 4660 nM
Estimate against measurement, compound 4: 1.3-fold (0.11 log units) above; measured number inside the range.
By their numbers in this assay, from the lowest: compounds 4, 3 and 1 (each within the scatter of the next). At a limit, above all of these: compound 2.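

With 4-chlorophenyl on the nitrogen, the number in this assay stays level with that of the cyclohexyl compound (a 1.3-fold lower number from compound 1 to compound 4 (0.11 log units; within the scatter)) and with that of the 3-chlorophenyl compound (a 1.0-fold lower number from compound 3 to compound 4 (0.01 log units; within the scatter)). The large gain from adding chloro to the phenyl group is therefore not confined to 3-chlorophenyl: it appears again with 4-chlorophenyl (an at least 10-fold lower number from compound 2 to compound 4 (1.03 log units; beyond the scatter)), matching the earlier step (an at least 10-fold lower number from compound 2 to compound 3 (1.01 log units; beyond the scatter)). Compound 2 stands at a limit of the assay and not at a number, so both steps are bounds only: the limit of > 50000 nM in this assay, at which 1 of the 4 values shown sits.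

The compounds shown leave open whether chloro itself is needed on the phenyl group, or whether methoxy, a nitrile or a dimethylamino group there would serve as well. They also leave open how 2-chlorophenyl, or a longer chain such as hexyl, would compare on that nitrogen.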